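Fluoro in Place of Hydrogen: Estimating Compound 3

A few compounds are considered here, and "the series" means these few. Any claim that something is new, unique, unknown or untested is made for them only; others in the source may bear on it.

Compound 1, `Cc1ccccc1N(C)C(=O)c1ccc(-c2ccc(O)cc2)o1`: 21 nM
Compound 2, `Cc1ccccc1N(C)C(=O)c1ccc(-c2ccc(O)cc2Cl)o1`: 14 nM

Of the compounds shown here, two have been measured in an assay on T47D cells for inhibition of 17-beta-hydroxysteroid dehydrogenase type 1 (Homo sapiens), read by HPLC, with a stated time of 24 h; a higher number here means a weaker inhibitor, a lower number a stronger inhibitor. Compound 1 gives 21 nM, which is the highest of the two numbers, and compound 2 gives 14 nM. The change between them is a 1.5-fold lower number from compound 1 to compound 2 (0.18 log units; within the scatter), so on these numbers the two compounds cannot be told apart.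

Compound 3, `Cc1ccccc1N(C)C(=O)c1ccc(-c2ccc(O)cc2F)o1`, is the next compound to consider. It differs from compound 1 in one place: fluoro in place of hydrogen on an aromatic carbon. Going by the values given here, only one measured step bears on this change, the one in which the same position carries chloro instead of hydrogen, and that step was a 1.5-fold lower number from compound 1 to compound 2 (0.18 log units; within the scatter). Fluoro is the smaller halogen placed at the very same position, and the chloro step gave no movement beyond the scatter, so no step beyond the scatter is expected here either, in either direction.

For compound 3 the expected result in this assay is therefore 18 nM, with a likely range from 9 nM to 40 nM, which corresponds to an expected step of a 1.2-fold lower number from compound 1 to compound 3 (0.07 log units; within the scatter).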

Compound 3, half-maximal inhibitory concentration: 10 nM
The estimate for compound 3 lay 1.8-fold (0.26 log units) above the measured number; the measured number falls inside the stated range.
By their numbers in this assay, from the lowest: compounds 3, 2 and 1 (each within the scatter of the next, the first and the last beyond it).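

In this assay, going by these compounds alone, the step with fluoro, a 2.1-fold lower number from compound 1 to compound 3 (0.32 log units; beyond the scatter), is the first at this position to lie beyond the scatter, which shows that a halogen here can move the number, though only modestly. Replacing one halogen with the other gives a 1.4-fold lower number from compound 2 to compound 3 (0.15 log units; within the scatter), and this puts compound 2 and compound 3 within the scatter of each other, so fluoro and chloro at this position cannot be told apart, even though only the fluoro step from compound 1 clears the scatter. Nothing available here explains why the number moves with either halogen.

The compounds shown leave open how this position responds to anything other than hydrogen, fluoro and chloro, such as bromo, a methyl group, a methoxy group or an amine, and so whether the modest gain belongs to halogens in particular or would appear with other small groups as well. They also leave open whether fluoro would give a similar step on the other carbons of this six-membered ring, since every change so far sits at the same place.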